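Methylselanyl for methylsulfanyl on the nitrothiophene bis-imide

A few compounds are considered here, and "the series" means these few. Any claim that something is new, unique, unknown or untested is made for them only; others in the source may bear on it.

Working notes on the series. The measured members are compound 1 `CS/C(=N\C(=O)c1ccco1)NC(=O)c1ccco1`, compound 2 `C[Se]/C(=N\C(=O)c1cnc2ccccc2c1)NC(=O)c1cnc2ccccc2c1` and compound 3 `CS/C(=N\C(=O)c1csc([N+](=O)[O-])c1)NC(=O)c1csc([N+](=O)[O-])c1`; compound 4 `C[Se]/C(=N\C(=O)c1csc([N+](=O)[O-])c1)NC(=O)c1csc([N+](=O)[O-])c1` is not yet measured. The read-out is a functional assay on HT-29 cells (Homo sapiens) for cytotoxicity, read by MTT assay, with a stated time of 72 h; on this read-out lower numbers stand for higher toxicity in this test and higher numbers for lower toxicity in this test. Compound 1 gives > 100000 nM, which is a limit of the assay and not a number. In this assay compound 2 gives > 100000 nM, again a limit. In this assay compound 3 gives > 100000 nM, also a limit. Compound 3 therefore stands exactly where the other two stand, at the limit of > 100000 nM in this assay, at which 3 of the 3 values shown sit. Since every shown value is a limit, no step between measured compounds can be sized.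

Compound 4 differs from compound 3 by a group of 2 heavy atoms (1 carbon, 1 selenium; no ring) in place of a group of 2 heavy atoms (1 carbon, 1 sulfur; no ring), on a carbon with a double bond to nitrogen. The group that enters in compound 4 is also carried by compound 2, whose result in this assay is likewise only a limit. With all three measured compounds at the limit, no shift beyond the usual scatter is expected from this change, in either direction. For compound 4 the expected value in this assay is 100000 nM, within 40000 nM to 300000 nM. The estimate means an expected step of a number no higher from compound 3 to compound 4 (the limit leaves the size open), and most likely compound 4 will again be reported as a limit.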

Compound 4, concentration lethal to 50% of the cells: > 100000 nM
Compound 4: only a limit was reported; the forecaster's own chance of this, stated with the estimate: 85%; the middle value lies on the limit itself.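

The step from compound 3 to compound 4 cannot be read, as both results are limits of the assay and not numbers: the limit of > 100000 nM in this assay, at which 4 of the 4 values shown sit. The compounds shown leave open whether exchanging methylsulfanyl for the selenium-carrying group changes the read-out at all, and what number any of the four compounds would give.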